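From Ethyl to Methoxy in a Tight Sulfonamide Series

The source may hold more compounds than are shown below. What is called first, only, known or untested is meant among the compounds shown, and "the series" means these compounds.

Compound 1 `CCc1cccc(NS(=O)(=O)c2ccc(N3CCNC3=O)cc2)c1` gives 230 nM in a functional assay on SK-OV-3 cells (Homo sapiens) for antiproliferative activity, read by sulforhodamine B assay, with a stated time of 48 h (a lower number here means a stronger inhibitor, a higher number a weaker inhibitor), and has two measured relatives for comparison. Compound 2 `O=C1NCCN1c1ccc(S(=O)(=O)Nc2cccc(Br)c2)cc1` gives 170 nM and compound 3 `Cc1cc(C)cc(NS(=O)(=O)c2ccc(N3CCNC3=O)cc2)c1` gives 190 nM in this assay as well. These three numbers all lie within the scatter of one another, so compound 1 holds no distinct place among them.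

Compound 4 `COc1cccc(NS(=O)(=O)c2ccc(N3CCNC3=O)cc2)c1` has not yet been measured. Its change from compound 1 is methoxy in place of ethyl on an aromatic carbon and the new group stands meta to a large group.

Among the compounds with values here, no measured compound carries methoxy, so the evidence is indirect. Bromo in place of ethyl gives a 1.4-fold lower number from compound 1 to compound 2 (0.13 log units; within the scatter) and 3,5-dimethylphenyl in place of 3-ethylphenyl gives a 1.2-fold lower number from compound 1 to compound 3 (0.08 log units; within the scatter) while the remaining exchange gives a 1.1-fold higher number from compound 2 to compound 3 (0.05 log units; within the scatter) in the same series. None of these steps leaves the scatter, so no step beyond the scatter is expected in this assay and no direction is favoured. The estimated step is a 1.1-fold lower number from compound 1 to compound 4 (0.04 log units; within the scatter) and it rests on that small spread alone. Compound 4 is expected at 210 nM with an estimated range of 100 nM to 450 nM on this reckoning.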

Compound 4, half-maximal inhibitory concentration: 240 nM
Compound 4: the middle estimate sits 1.1-fold (0.06 log units) below what was measured; the measured number falls inside the stated range.
By their numbers in this assay, from the lowest: compounds 2, 3, 1 and 4 (each within the scatter of the next).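

In this assay, within the data shown here, methoxy in place of ethyl on this aromatic carbon, meta to a large group, gives a 1.0-fold higher number from compound 1 to compound 4 (0.02 log units; within the scatter) even though the entering group brings an oxygen and a hydrogen-bond acceptor that ethyl lacks, so the earlier comparisons among bromo, ethyl and dimethyl patterns are now joined by a first oxygen-bearing group without any step leaving the scatter. The other two comparisons agree, with methoxy in place of bromo giving a 1.4-fold higher number from compound 2 to compound 4 (0.15 log units; within the scatter) and 3-methoxyphenyl in place of 3,5-dimethylphenyl giving a 1.3-fold higher number from compound 3 to compound 4 (0.10 log units; within the scatter) in the same series, so all four compounds now stand within the scatter of one another and none holds a distinct place. Nothing available accounts for this flatness.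

From the compounds shown here alone, whether an amine, a carboxylic acid or a longer chain on this aromatic carbon would produce a step beyond the scatter stays open, as the four compounds span only small groups here. Going by these compounds, it also stays open whether methoxy would behave the same way elsewhere on this ring, or with a change made in the shared core.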